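Moving the Chlorine on the Benzyl Side Chain

The compounds below may be only part of what the source reports. "The series", "measured", "known", "first", "only" and "open" are said of these compounds alone.

Three compounds share one core and differ only in a group on an aromatic carbon. Compound 1 `CCC1(Cc2ccccc2)OS(=O)(=O)C=C1OCc1ccc([N+](=O)[O-])cc1` carries a nitro group, compound 2 `CCC1(Cc2ccccc2)OS(=O)(=O)C=C1OCc1ccc(C)cc1` a methyl, compound 3 `CCC1(Cc2ccccc2)OS(=O)(=O)C=C1OCc1ccc(Cl)cc1` a chloro. In an ADME assay on HEL cells (Homo sapiens) for cytotoxicity, with a stated time of 3 days (on this read-out lower numbers stand for higher toxicity in this test and higher numbers for lower toxicity in this test), compound 1 gives >= 80000 nM, which is a limit of the assay rather than a number. Compound 2 gives >= 16000 nM, also a limit. Compound 3 gives >= 50000 nM, again only a limit. The steps a step that the two limits leave unreadable from compound 1 to compound 2, a step that the two limits leave unreadable from compound 1 to compound 3 and a step that the two limits leave unreadable from compound 2 to compound 3 therefore cannot be read in size or direction. Compound 4 `CCC1(Cc2ccccc2)OS(=O)(=O)C=C1OCc1ccccc1Cl` differs from compound 3 by 2-chlorophenyl in place of 4-chlorophenyl on a saturated chain carbon bound to an oxygen on an unsaturated carbon. For the measured compounds named here, no measured step bears on this change, so no shift beyond the scatter is expected. Compound 4 is expected to give 50000 nM, between 20000 nM and 100000 nM. The expected step is a number no higher from compound 3 to compound 4 (the limit leaves the size open), likely again only a limit.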

Compound 4, minimum cytotoxic concentration: >= 20000 nM
Compound 4: only a limit was reported (the forecaster's own chance of this, stated with the estimate: 80%); the middle value is on the limit's open side.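

Compound 4, like compound 1, compound 2 and compound 3, is reported only as a limit, and its steps from those three cannot be read in size or direction. The compounds shown leave open whether 2-chlorobenzyl in place of 4-chlorobenzyl changes the result in this assay at all.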